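Ester for Amide on a Fused Core: Compound 3 Awaited

The source may report more compounds than this note shows. Statements on the series, on what has been measured and on what is new or still open speak of the compounds shown alone.

Measured so far:
compound 1, `CC(=O)Nc1c(C)nc2c(CCc3ccccc3)cccn12`: 40%
compound 2, `Cc1nc2c(OCc3ccccc3)cccn2c1NC(=O)OCc1ccccc1`: 8%

Of the compounds shown here, two have been measured in a functional assay on the whole organism with Rattus norvegicus as the target, at a dose of 40 mg/kg by the intraperitoneal route; on this read-out lower numbers stand for less inhibition and higher numbers for more inhibition at the one dose given (going by the name of the read-out). Compound 1 `CC(=O)Nc1c(C)nc2c(CCc3ccccc3)cccn12` gives 40% in this assay. Compound 2 `Cc1nc2c(OCc3ccccc3)cccn2c1NC(=O)OCc1ccccc1` gives 8% in this assay. Compound 1 therefore stands highest of the two numbers shown, and its nearest neighbour, compound 2, lies lower by a gap that is beyond the usual scatter. Within the data shown here, compound 2 differs from compound 1 in more than one place at once, so no single step between measured compounds can be drawn from the pair; the two values show only that the two whole structures give clearly different inhibition.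

Compound 3 `COC(=O)c1c(C)nc2c(CCc3ccccc3)cccn12` is the compound yet to be measured. Its difference from compound 1 is methoxycarbonyl in place of acetamido on an aromatic carbon. Among the measured compounds shown here, no measured pair isolates this change, so the expectation rests on compound 1 alone. The step of a number 15 percentage points lower from compound 1 to compound 3 (beyond the scatter) is expected to be a moderate fall, beyond the scatter but not to the floor of the read-out. Compound 3 is accordingly estimated at 25%, in a range from 5% to 48%, in this assay.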

Compound 3, a percentage reported as inhibition, in the whole organism at one dose (the size of the read-out at that dose, not a potency): 64%
Beside the measured number, compound 3's estimate is 39 percentage points below it; measured number outside the range, above it.
By their numbers in this assay, from the lowest: compound 2; then compound 1; then compound 3.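

On the core shared by compound 1 and compound 3, the aromatic carbon of the five-membered ring, next to the ring nitrogen, proves open to change: in this assay methoxycarbonyl in place of acetamido gives a number 24 percentage points higher from compound 1 to compound 3 (beyond the scatter) at the one dose given. Among these compounds, this is the first pair here that differs in one place, so it ties a change in the read-out to this position, which compound 1 and compound 2 could not do; it also shows that the hydrogen-bond donor of acetamido, absent from methoxycarbonyl, is not required for the higher number in this pair. No measurement shown bears on why the number rises with this change.

From the compounds shown here alone, whether a carboxylic acid, an ethyl ester or a simple amine on this same aromatic carbon would read above or below methoxycarbonyl remains open. Among the compounds shown here, also open is whether methoxycarbonyl would give a similar step on a core carrying another group in place of the one shared by compound 1 and compound 3, and a single dose leaves potency itself unresolved.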